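Three Phenoxy Ketones Measured, a Trifluorophenyl Analogue Expected

The compounds below may be only part of what the source reports. "The series", "measured", "known", "first", "only" and "open" are said of these compounds alone.

Measured so far in a functional assay with Homo sapiens as the target; a lower number here means a stronger inhibitor, a higher number a weaker inhibitor:
compound 1 `CC(C)[C@H](NC(=O)COc1cccc2ccccc12)C(=O)N[C@@H](CC(=O)O)C(=O)COC(=O)c1c(Cl)cccc1Cl` gives 11500 nM;
compound 2 `CC(C)[C@H](NC(=O)COc1cccc2ccccc12)C(=O)N[C@@H](CC(=O)O)C(=O)COc1ccccc1` gives 11200 nM;
compound 3 `CC(C)[C@H](NC(=O)COc1cccc2ccccc12)C(=O)N[C@@H](CC(=O)O)C(=O)COc1cccc(F)c1` gives 12000 nM.

Compound 3 has the highest of the three numbers, yet the gaps to it are small: a 1.0-fold higher number from compound 1 to compound 3 (0.02 log units; within the scatter) and a 1.1-fold higher number from compound 2 to compound 3 (0.03 log units; within the scatter) both sit within the scatter, so no order among the three can be claimed. Compound 4 `CC(C)[C@H](NC(=O)COc1cccc2ccccc12)C(=O)N[C@@H](CC(=O)O)C(=O)COc1cc(F)c(F)cc1F` differs from compound 3 by 2,4,5-trifluorophenyl in place of 3-fluorophenyl on an oxygen on a saturated carbon. For the measured compounds named here, the steps that bear on this change are a 1.1-fold higher number from compound 2 to compound 3 (0.03 log units; within the scatter), where a fluoro entered on the same ring, and a 1.0-fold lower number from compound 1 to compound 2 (0.01 log units; within the scatter) together with a 1.0-fold higher number from compound 1 to compound 3 (0.02 log units; within the scatter), where the whole group on that oxygen was exchanged; none of them moved beyond the scatter. Compound 4 is therefore expected to show no change at the digits printed from compound 3 to compound 4 (within the scatter), nothing beyond the scatter. Compound 4 is estimated at 12000 nM, within 6000 nM to 24000 nM.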

Compound 4, half-maximal inhibitory concentration: 16700 nM
Compound 4: middle estimate off by 1.4-fold (0.14 log units), on the low side, within the range that was stated.
By their numbers in this assay, from the lowest: compounds 2, 1, 3 and 4 (each within the scatter of the next).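

With 2,4,5-trifluorophenyl on this oxygen, this assay gives a 1.4-fold higher number from compound 3 to compound 4 (0.14 log units; within the scatter) and a 1.5-fold higher number from compound 2 to compound 4 (0.17 log units; within the scatter) and a 1.5-fold higher number from compound 1 to compound 4 (0.16 log units; within the scatter). These are the largest steps yet at this position, but all remain within the scatter, so the four compounds still cannot be ordered. No other evidence bears on this result. On these data alone, it remains open whether an amine or a carboxylic acid on the phenyl ring, or a longer chain between the oxygen and that ring, would move the number beyond the scatter.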